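The source may hold more compounds than are shown below. What is called first, only, known or untested is meant among the compounds shown, and "the series" means these compounds.

Measured so far in a functional assay on CWR22R cells (Homo sapiens) for antiproliferative activity, read by CCK-8 assay, with a stated time of 6 days; on this read-out lower numbers stand for stronger inhibition and higher numbers for weaker inhibition:
compound 1 `C[C@@H](Cn1ccc(-c2ccc(C#N)c(Cl)c2)n1)NC(=O)c1ccccc1` gives "not determined" (no result reported)
compound 2 `C[C@@H](Cn1ccc(-c2ccc(C#N)c(Cl)c2)n1)NC(=O)C1CC(=O)C1` gives "not determined" (no result reported)
compound 3 `C[C@@H](Cn1ccc(-c2ccc(C#N)c(Cl)c2)n1)Nc1cccnc1` gives 21600 nM

The series offers a single number to work from. Compound 3, at 21600 nM in this assay, is the only one of the three with a measured value. Compound 1 and compound 2 have no reported result, so compound 3 cannot be ranked against either of them.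

The next compound is compound 4 `C[C@@H](Cn1ccc(-c2ccc(C#N)c(Cl)c2)n1)Nc1ccncc1`, which has not yet been measured. It contains the same atoms as compound 3, joined differently. The change is pyridin-4-yl in place of pyridin-3-yl on an amine nitrogen and in words it is pyridin-4-yl in place of pyridin-3-yl on an amine nitrogen. Among the compounds with values here, no pair of measured compounds shows what a change of this kind does. The expectation therefore rests on the structural change alone, and it favours no direction. Within the data shown here, no shift beyond the usual scatter is expected in this assay, although the uncertainty is wide with only one measured value available. This estimate amounts to an expected 1.1-fold lower number from compound 3 to compound 4 (0.03 log units; within the scatter) in the assay. For compound 4 the estimated value is 20000 nM, with an expected range from 7000 nM to 50000 nM.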

Compound 4, half-maximal inhibitory concentration: 11500 nM
Beside the measured number, compound 4's estimate is 1.7-fold (0.24 log units) above it; measured number inside the range.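

In this assay, within the data shown here, pyridin-4-yl in place of pyridin-3-yl on the amine nitrogen gives a 1.9-fold lower number from compound 3 to compound 4 (0.27 log units; within the scatter) and so provides the first step that can be read. At this position, on an amine nitrogen whose other neighbour is a saturated chain carbon, this read-out does not separate the two pyridine attachments, with compound 3 at 21600 nM and compound 4 at 11500 nM lying within the usual scatter of each other. No other information at hand bears on this result.

The compounds shown leave open whether another group on this amine nitrogen, such as pyridin-2-yl, a plain phenyl ring or a pyrimidin-5-yl ring with a second ring nitrogen, would give a number beyond the scatter of these two. On these data alone, compound 1 and compound 2 have no reported result, so it also remains open how the benzamide of compound 1 and the amide with a four-membered ketone ring in compound 2 compare with the pyridine-bearing amines.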